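Compound 3 to compound 4: swapping the amide group

The source may report more compounds than this note shows. Statements on the series, on what has been measured and on what is new or still open speak of the compounds shown alone.

In a functional assay with Oryctolagus cuniculus as the target (on this read-out lower numbers stand for stronger inhibition and higher numbers for weaker inhibition), compound 3 (`COc1ccc(-c2nc(C(=O)N3CCCCC3)sc2-c2ccc(OC)cc2)cc1`) gives > 1000 nM, a limit and not a number. Compound 1 (`COc1ccc(-c2nc(/N=C(\N)NC3CCCCC3)sc2-c2ccc(OC)cc2)cc1`) gives > 1000 nM, also a limit. Compound 2 (`COc1ccc(-c2nc(C(=O)N(C)C)sc2-c2ccc(OC)cc2)cc1`) gives < 100 nM, again a limit. Compound 3 therefore stands at the limit of > 1000 nM in this assay, at which 2 of the 3 values shown sit.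

Compound 4 (`COc1ccc(-c2nc(C3=CCN(C)CC3)sc2-c2ccc(OC)cc2)cc1`) differs from compound 3 by a group of 7 heavy atoms (6 carbon, 1 nitrogen; one six-membered non-aromatic ring with 1 hetero atom) in place of a group of 8 heavy atoms (6 carbon, 1 nitrogen, 1 oxygen; one six-membered non-aromatic ring with 1 hetero atom), on an aromatic carbon. The nearest evidence is an at least 10-fold higher number from compound 2 to compound 3 (1.00 log units; beyond the scatter), and an at least 10-fold lower number from compound 1 to compound 2 (1.00 log units; beyond the scatter) also shows that this place can move the read-out. The third step, a step that the two limits leave unreadable from compound 1 to compound 3, adds no size. None of these steps removes the carbonyl, and the six-membered ring stays, so only a weak guide exists. The expected change is a step that the limit leaves unreadable from compound 3 to compound 4, with no firm direction. For compound 4 the estimated value is 1500 nM, with an expected range of 200 nM to 10000 nM.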

Compound 4, half-maximal inhibitory concentration: < 10 nM
Compound 4: no number, only a limit; the forecaster's own chance of this, stated with the estimate: 55%; at least 150-fold (2.17 log units) between middle value and limit.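

In this assay, a group with no carbonyl at this position reaches the strong end of the series, with an at least 100-fold lower number from compound 3 to compound 4 (2.00 log units; beyond the scatter) and an at least 100-fold lower number from compound 1 to compound 4 (2.00 log units; beyond the scatter), so an amide is not required here. Compound 4 gives < 10 nM, a limit of the assay and not a number. The step between compound 2 and compound 4 cannot be read, as both values are limits.

Going by these compounds, how much compound 4 truly gains remains open. Also open, on these data alone, is whether a saturated 1-methylpiperidin-4-yl group or a ring lacking the methyl would keep this strength.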